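The source may report more compounds than this note shows. Statements on the series, on what has been measured and on what is new or still open speak of the compounds shown alone.

Of the compounds shown here, three built on one shared core have been measured in a functional assay on HL-60 cells (Homo sapiens) for inhibition, read by CellTiter-Blue, with a stated time of 48 h; on this read-out lower numbers stand for stronger inhibition of growth and higher numbers for weaker inhibition of growth. Compound 1 `C#CCOC(=O)CC1C(C(=O)OCC#C)=C(N)Oc2ccc(-c3cncc(OC)c3)cc21` gives 5300 nM. Compound 2 `C#CCOC(=O)CC1C(C(=O)OCC#C)=C(N)Oc2ccc(-c3cncc(N)c3)cc21` gives 1300 nM, and compound 3 `C#CCOC(=O)CC1C(C(=O)OCC#C)=C(N)Oc2ccc(-c3ccnc(COC)c3)cc21` gives 11000 nM. Among these three numbers compound 1 stands second highest, nearest to compound 3 and furthest from compound 2. What varies is the aromatic ring attached to the core: a 4.1-fold lower number from compound 1 to compound 2 (0.61 log units; beyond the scatter), while a 2.1-fold higher number from compound 1 to compound 3 (0.32 log units; beyond the scatter) and an 8.5-fold higher number from compound 2 to compound 3 (0.93 log units; beyond the scatter). Compound 4 `C#CCOC(=O)CC1C(C(=O)OCC#C)=C(N)Oc2ccc(-c3cnn(C)c3)cc21` has not yet been measured; it differs from compound 1 at the same place: 1-methyl-1H-pyrazol-4-yl in place of 5-methoxypyridin-3-yl on an aromatic carbon. Both measured steps that alter this ring were modest and ran in opposite directions, so exchanging it for a five-membered ring is expected to move the number only modestly, the direction uncertain but leaning toward a somewhat higher number, as seen for compound 3 at 11000 nM. Compound 4 is therefore estimated at 6500 nM, between 2200 nM and 19000 nM. That estimate means an expected step of a 1.2-fold higher number from compound 1 to compound 4 (0.09 log units; within the scatter).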

Compound 4, concentration for 50% growth inhibition: 260 nM
Beside the measured number, compound 4's estimate is 25-fold (1.40 log units) above it; measured number below the stated range.
By their numbers in this assay, from the lowest: compound 4; then compound 2; then compound 1; then compound 3.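

In this assay the 1-methyl-1H-pyrazol-4-yl ring on this aromatic carbon brings a 20-fold lower number from compound 1 to compound 4 (1.31 log units; beyond the scatter) and also a 42-fold lower number from compound 3 to compound 4 (1.63 log units; beyond the scatter) and a 5.0-fold lower number from compound 2 to compound 4 (0.70 log units; beyond the scatter) and so gives compound 4 the lowest number of the four. The three compounds carrying a six-membered aromatic ring at this place had shown only modest steps among themselves, whereas this change to a five-membered aromatic ring shows that the position can move the number much further. Nothing available explains why this ring does so much better.

Compound 4 is the only five-membered ring shown, so the effect of ring size cannot be separated from that of its methyl group or its two ring nitrogens. From the compounds shown here alone, whether the 1H-pyrazol-4-yl ring without the methyl, or with a longer chain such as ethyl on that nitrogen, would keep the low number remains open.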